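This account rests on a few compounds, and the source may have more. Where it says the series, first, only, none or still open, it means among the compounds named here.

Measured compounds:
Compound 1 `CC(=O)OCCc1c(C)nc(Cl)nc1Cl` — in a functional assay on NCI-H460 cells (Homo sapiens) for antiproliferative activity, read by MTT assay, with a stated time of 24 h (a higher number here means a weaker inhibitor, a lower number a stronger inhibitor), compound 1 gives > 100000 nM, which is a limit of the assay and not a number.
Compound 2 `COc1nc(Cl)nc(C)c1CCOC(C)=O` — in this assay compound 2 gives > 100000 nM, likewise a limit.

Within the data shown here, compound 1 therefore stands only at a limit, and the one further value shown is a limit as well, so its position relative to compound 2 cannot be read. The step from compound 1 to compound 2, a step that the two limits leave unreadable from compound 1 to compound 2, methoxy in place of chloro on an aromatic carbon, has no readable size for the same reason; both values sit together at the limit of > 100000 nM in this assay, at which 2 of the 2 values shown sit.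

Compound 3 `Cc1nc(Cl)nc(Cl)c1CCCl` differs from compound 1 by chloro in place of acetoxy on a saturated chain carbon, two bonds along the chain from an aromatic carbon. No measured step touches the saturated chain; the only step shown lies on the aromatic ring and is itself unreadable. What is known gives neither a size nor a direction for the change in this assay, and the expectation rests entirely on (the limit of > 100000 nM in this assay, at which 2 of the 2 values shown sit). Compound 3 is expected at 150000 nM, with a range from 40000 nM to 600000 nM, most probably returned as a limit again. The implied step that the limit leaves unreadable from compound 1 to compound 3 is expected to stay within the scatter.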

Compound 3, half-maximal inhibitory concentration: 3000 nM
The estimate for compound 3 lay 50-fold (1.70 log units) above the measured number; measured number outside the range, below it.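

Among these compounds, the saturated chain is a place that responds in this assay, which the one step on the aromatic ring could not show: the step here is an at least 33-fold lower number from compound 1 to compound 3 (1.52 log units; beyond the scatter), the first readable step and a large one. It comes from a single change, chloro in place of acetoxy on a saturated chain carbon, two bonds along the chain from an aromatic carbon, with the rest of the core of compound 1 untouched, so this one place alone is enough to bring a value into the readable range. Compound 3 is the only compound shown with a value off the limit: the limit of > 100000 nM in this assay, at which 2 of the 3 values shown sit.

Going by these compounds, whether the step reflects the arrival of chloro or the departure of acetoxy stays open, and a hydroxy group, an amine or a longer chain at the same carbon would begin to separate the two. On these data alone, the step from compound 1 to compound 2 cannot be read, so it also stays open whether methoxy in place of chloro on an aromatic carbon would matter in a compound carrying the chloro chain of compound 3.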